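Phenyl to Cyclohexyl on Compound 1: A Permeability Estimate

The source may hold more compounds than are shown below. What is called first, only, known or untested is meant among the compounds shown, and "the series" means these compounds.

- compound 1 `O=C(NCc1cc(Cl)ccc1-n1cnnn1)[C@@H]1CC=NN1C(=O)[C@H](O)c1ccccc1`: 7 10^-6 cm/s
- compound 2 `CC(C)(C)[C@@H](O)C(=O)N1C[C@@H]2C[C@@H]2[C@H]1C(=O)NCc1cc(Cl)ccc1-n1cnnn1`: 17 10^-6 cm/s
- compound 3 `CCCC(=O)O[C@@H](C(=O)N1N=CC[C@H]1C(=O)NCc1cc(Cl)ccc1-n1cnnn1)c1ccc(F)cc1`: 25 10^-6 cm/s

All three compounds were tested in an ADME assay on Caco-2 cells (Homo sapiens) for permeability, read by LC-MS, in the apical to basolateral direction, with a stated time of 60 min, at pH 6.5; on this read-out higher numbers stand for higher permeability and lower numbers for lower permeability. Compound 1 has the lowest of the three numbers, with compound 2 nearest above it and compound 3 furthest; both gaps lie beyond the usual scatter.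

Compound 4 `O=C(NCc1cc(Cl)ccc1-n1cnnn1)[C@@H]1CC=NN1C(=O)[C@H](O)C1CCCCC1` has not yet been measured. Its structure departs from that of compound 1 in one place: cyclohexyl in place of phenyl on a saturated chain carbon bound to a carbonyl carbon and an oxygen on a saturated carbon. This puts cyclohexyl in place of phenyl on a saturated chain carbon bound to a carbonyl carbon and an oxygen on a saturated carbon.

Among the measured compounds shown here, no measured pair isolates this change, so the expectation is loose. Compound 2, which has no phenyl group and a different core, gives 17 10^-6 cm/s, a weak hint of a rise. Compound 3 goes against that hint, keeping an aromatic ring and giving 25 10^-6 cm/s. A small upward move, perhaps none beyond the scatter, is expected, with an estimated 1.7-fold higher number from compound 1 to compound 4 (0.23 log units; within the scatter). For compound 4 the expected value in this assay is 12 10^-6 cm/s, within an estimated range of 6 10^-6 cm/s to 24 10^-6 cm/s.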

Compound 4, apparent permeability: 19 10^-6 cm/s
For compound 4 the middle estimate is 1.6-fold (0.20 log units) below the measured one; the measured number falls inside the stated range.
By their numbers in this assay, from the lowest: compound 1; then compounds 2, 4 and 3 (each within the scatter of the next).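

Cyclohexyl in place of phenyl on a saturated chain carbon bound to a carbonyl carbon and an oxygen on a saturated carbon gives a 2.7-fold higher number from compound 1 to compound 4 (0.43 log units; beyond the scatter) in this assay, the first step here in which only this group differs. The two groups match in heavy atoms, hydrogen-bond donors, hydrogen-bond acceptors and net charge, and the computed comparison separates them by one feature: the six-membered ring is aromatic in phenyl and non-aromatic in cyclohexyl. Nothing at hand explains why the number moves.

Going by these compounds, whether the same step holds on another core remains open, since this is a single pair. Also open, on these data alone, is how this assay would respond at this position to a cyclopentyl ring, a pyridyl ring or a cyclohexyl ring carrying an amine.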